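The compounds below may be only part of what the source reports. "The series", "measured", "known", "first", "only" and "open" are said of these compounds alone.

Measured so far:
Compound 1, `CCCC(Nc1ccc(-n2cc(C(F)(F)F)cn2)nc1)c1ccc(C(=O)NCCC(=O)O)cc1`, 170 nM
Compound 2, `O=C(O)CCNC(=O)c1ccc(C(Oc2ccc(-n3cc(C(F)(F)F)cn3)cc2)C2CCCC2)cc1`, 420 nM

Both compounds were tested in an assay on cells for displacement of a labelled ligand from Glucagon receptor (Homo sapiens), in the presence of a further agent that is not named here; on this read-out lower numbers stand for stronger inhibition and higher numbers for weaker inhibition. Of the two numbers, compound 2 has the higher one, so it is the weaker inhibitor of the pair; the nearest value belongs to compound 1, whose lower number lies beyond the usual scatter of this assay. Going by the values given here, no single-point step between the two measured compounds can be described, since they differ in more than one place: the oxygen-linked ring in compound 2 stands against the nitrogen-linked ring in compound 1, and the cyclopentyl against the propyl.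

Compound 3, `CCCC(Oc1ccc(-n2cc(C(F)(F)F)cn2)cc1)c1ccc(C(=O)NCCC(=O)O)cc1`, has not yet been measured. It differs from compound 2 in one place: propyl in place of cyclopentyl on a saturated chain carbon bound to an aromatic carbon and an oxygen on an aromatic ring. Compound 1, which also carries a propyl at this position, gives 170 nM, but its other difference from compound 2 keeps that from being a clean guide. The expected step from compound 2 to compound 3 is a 1.4-fold lower number from compound 2 to compound 3 (0.15 log units; within the scatter), a modest move toward a lower number that may well stay inside the scatter. Compound 3 is therefore expected to give about 300 nM, within a range from 120 nM to 800 nM.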

Compound 3, inhibition constant: 890 nM
Beside the measured number, compound 3's estimate is 3.0-fold (0.47 log units) below it; measured number above the stated range.
By their numbers in this assay, from the lowest: compound 1; then compound 2; then compound 3.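

In this assay, propyl in place of cyclopentyl on a saturated chain carbon bound to an aromatic carbon and an oxygen on an aromatic ring gives a 2.1-fold higher number from compound 2 to compound 3 (0.33 log units; beyond the scatter). Going by these compounds alone, this is the first change here that can be read on its own, since compound 1 and compound 2 differ in more than one place, and it shows that the group at this position affects the number: with everything else held constant, cyclopentyl gives the stronger inhibition of the two. Nothing measured alongside these numbers accounts for the step, so it stands as an observation only.

The step swaps a ring for an open chain and also removes carbons, so it cannot tell which of the two matters; a pentyl chain or a cyclohexyl ring at this place would help separate them. Steps involving compound 1 cannot be read, as no compound shown differs from it in one place, so the effect of its nitrogen link remains open.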